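The source may report more compounds than this note shows. Statements on the series, on what has been measured and on what is new or still open speak of the compounds shown alone.

Working notes on a set of antagonists of the shared core.

Going by the values given here, compound 1 `Cc1ccc(-c2c(O)nc3cc(Cl)c([N+](=O)[O-])cc3c2OCCC2CCCCN2)c(C)c1` is the weakest of the three measured members: in a functional assay on cells (Pituitary gland cell) for antagonist activity at Gonadotropin-releasing hormone receptor (Rattus norvegicus) (on this read-out higher numbers stand for weaker inhibition and lower numbers for stronger inhibition), compound 1 gives 400 nM, the highest number in the set. Compound 2 `Cc1cc(C)cc(-c2c(O)nc3cc(Cl)c(NC(=O)c4cnccn4)cc3c2OCCC2CCCCN2)c1` gives 1.8 nM in this assay, and compound 3 `O=C(Nc1cc2c(OCCC3CCCCN3)c(-c3ccc4ccccc4c3)c(O)nc2cc1Cl)NC1CC1` gives 68 nM. Both gaps to compound 1 lie beyond the scatter. Compounds 2 and 3 each differ from compound 1 in more than one place, so no single change is isolated among the measured members, and the aryl group on the core cannot be separated from the changes on the fused ring.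

Compound 4 `O=[N+]([O-])c1cccc(-c2c(O)nc3cc(Cl)c([N+](=O)[O-])cc3c2OCCC2CCCCN2)c1` is the unmeasured member. It differs from compound 1 by a single exchange: 3-nitrophenyl in place of 2,4-dimethylphenyl on an aromatic carbon. Among the compounds with values here, no measured pair shows the effect of this exchange alone. The dimethylphenyl is kept in compound 2 at a different substitution pattern, the nitro on the fused ring is kept in compound 1 only. With nothing to anchor the direction, a step of modest size, toward weaker inhibition or none beyond the scatter, is expected, a 2.0-fold higher number from compound 1 to compound 4 (0.30 log units; within the scatter). For compound 4 the estimate in this assay is 800 nM, with a range from 200 nM to 3500 nM.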

Compound 4, half-maximal inhibitory concentration: 100 nM
Estimate against measurement, compound 4: 8.0-fold (0.90 log units) above; the measured number lies below the stated range.
By their numbers in this assay, from the lowest: compound 2; then compounds 3 and 4 (each within the scatter of the next); then compound 1.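

In this assay, going by these compounds alone, 3-nitrophenyl in place of 2,4-dimethylphenyl gives a 4.0-fold lower number from compound 1 to compound 4 (0.60 log units; beyond the scatter), the only single change isolated so far. It shows that the aryl group on this aromatic carbon, ortho to the hydroxy group and ortho to the 2-(piperidin-2-yl)ethoxy group, moves the read-out on its own while the rest of the molecule stays fixed, and that the two methyl groups are not needed to reach this level of inhibition. No measurement at hand accounts for the step.

The compounds shown leave open whether the step comes from losing the methyl groups or from gaining the nitro group, which a plain phenyl or a 3-methylphenyl would help separate. A 3-aminophenyl or 3-methoxyphenyl at the same carbon would test whether the nitro group itself matters.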